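Aryl for benzyl on the ring nitrogen: cytotoxicity notes

The source may hold more compounds than are shown below. What is called first, only, known or untested is meant among the compounds shown, and "the series" means these compounds.

Compound 1 `COc1ccc(C[C@H]2COC(=O)[C@@H]2Cc2ccc(OCc3cn(Cc4ccccc4F)nn3)c(OC)c2)cc1OC` gives in an ADME assay on HeLa cells (Homo sapiens) for cytotoxicity, read by MTT assay (on this read-out lower numbers stand for stronger inhibition and higher numbers for weaker inhibition), only a limit, >= 600000 nM; this is the limit of >= 600000 nM in this assay, at which 1 of the 3 values shown sits. Compound 2 `CCN1CCN(C(=O)CCC(=O)Oc2ccc(C[C@H]3C(=O)OC[C@@H]3Cc3ccc(OC)c(OC)c3)cc2OC)CC1` gives 190000 nM in this assay. For the measured compounds named here, compound 3 `COC(=O)[C@H](CC(C)C)NC(=O)CCC(=O)Oc1ccc(C[C@H]2C(=O)OC[C@@H]2Cc2ccc(OC)c(OC)c2)cc1OC` gives 53200 nM in this assay, and the step of a 3.6-fold lower number from compound 2 to compound 3 (0.55 log units; beyond the scatter) is the only measured step in the set. Compound 4 `COc1ccc(C[C@H]2COC(=O)[C@@H]2Cc2ccc(OCc3cn(-c4cccc(Cl)c4)nn3)c(OC)c2)cc1OC` differs from compound 1 by 3-chlorophenyl in place of 2-fluorobenzyl on an aromatic nitrogen. Going by the values given here, the one measured step concerns a substituent on a carbonyl carbon in a different part of the shared core, so no measured step bears on the change at the aromatic nitrogen; no step beyond the scatter is expected, and compound 4 is expected to stay at the limit. Compound 4 is estimated at 800000 nM, between 300000 nM and 2000000 nM, a step that the limit leaves unreadable from compound 1 to compound 4.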

Compound 4, half-maximal inhibitory concentration: 493000 nM
Compound 4: middle estimate off by 1.6-fold (0.21 log units), on the high side; measured number inside the range.
By their numbers in this assay, from the lowest: compound 3; then compound 2; then compound 4. At a limit, above all of these: compound 1.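

In this assay, 3-chlorophenyl in place of 2-fluorobenzyl on an aromatic nitrogen gives an at least 1.2-fold lower number from compound 1 to compound 4 (0.08 log units; that floor lies within the scatter). With 3-chlorophenyl at this position, the series has a readable number rather than a limit, so the group on this nitrogen can be followed by value. The true size of the step cannot be read because compound 1 stands at a limit: the limit of >= 600000 nM in this assay, at which 1 of the 4 values shown sits.

Going by these compounds, the change swaps the halogen and removes the benzyl carbon together, so their separate contributions remain open. A 3-chlorobenzyl or an unsubstituted phenyl on this nitrogen would separate them.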